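The source may report more compounds than this note shows. Statements on the series, on what has been measured and on what is new or still open speak of the compounds shown alone.

Among the measured compounds shown here, compound 2 `COC1=C(Br)C(=O)[C@]2(C=C1Br)CO2` is the only compound in this set for which a plain number is known. In an ADME assay on BAEC cells (Bos taurus) for cytotoxicity, read by MTT assay, with a stated time of 2 days (a higher number here means a weaker inhibitor, a lower number a stronger inhibitor), compound 2 gives 161000 nM, a weak effect. For the measured compounds named here, the one other measured compound, compound 1 `COc1c(Br)cc(CO)c(O)c1Br`, gives no number there. For compound 1 the readout in this assay is > 16000 nM, which is a limit of the assay rather than a measured concentration. So the limit of > 16000 nM in this assay, at which 1 of the 2 values shown sits, means that compound 2 stands alone as the single number shown, with nothing to rank it against.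

Compound 3 `COC1=C(Br)C(=O)[C@@]2(CO2)C(OC)=C1Br` differs from compound 2 by methoxy in place of hydrogen on a double-bonded ring carbon. Going by the values given here, no pair of measured compounds shows this change, so there is nothing to carry over. The expected step from compound 2 to compound 3 is a 1.1-fold lower number from compound 2 to compound 3 (0.03 log units; within the scatter), which is nothing beyond the usual scatter. Compound 3 is therefore estimated at 150000 nM, in a range from 50000 nM to 450000 nM.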

Compound 3, half-maximal inhibitory concentration: > 15000 nM
Compound 3: only a limit was reported; the forecaster's own chance of this, stated with the estimate: 30%; the middle value does not contradict the limit.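

The step from compound 2 to compound 3 cannot be read: for compound 3 the result is only a limit of the assay, not a number. The compounds shown leave open whether methoxy in place of hydrogen on a double-bonded ring carbon changes the number in this assay at all.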